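Working notes: from compound 2 to compound 3

This account rests on a few compounds, and the source may have more. Where it says the series, first, only, none or still open, it means among the compounds named here.

Measured in a functional assay on MCF7 cells (Homo sapiens) for cytotoxicity, read by MTT assay, with a stated time of 24 h; a higher number here means a weaker inhibitor of growth, a lower number a stronger inhibitor of growth:
- compound 1 `COc1cccc(/C=C/C(=O)c2ccc(OCC=C(C)C)cc2O)c1OC`: > 100000 nM
- compound 2 `COc1ccc(/C=C/C(=O)c2ccc(OCC=C(C)C)cc2O)c(OC)c1OC`: > 100000 nM

Compound 2 stands at > 100000 nM, which is a limit and not a number. The value of compound 1 is also a limit. Neither compound has a number to serve as a starting point: the limit of > 100000 nM in this assay, at which 2 of the 2 values shown sit.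

Compound 3 `COc1ccc(/C=C/C(=O)c2ccc(OCC=C(C)C)cc2OCC=C(C)C)c(OC)c1OC` differs from compound 2 by 3-methylbut-2-en-1-yl in place of hydrogen on an oxygen on an aromatic ring. The same difference reads hydroxy to (3-methylbut-2-en-1-yl)oxy.

Within the data shown here, the only measured step is a step that the two limits leave unreadable from compound 1 to compound 2. It involves methoxy in place of hydrogen on an aromatic carbon, a different change, and it gives no size to carry over. No size or direction can therefore be taken from the data for this assay, and no step beyond the scatter is expected. The expected step is a number no higher from compound 2 to compound 3 (the limit leaves the size open). Compound 3 is estimated at 100000 nM, with an expected range from 30000 nM to 300000 nM.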

Compound 3, concentration for 50% growth inhibition: 92000 nM
Compound 3: the middle estimate sits 1.1-fold (0.04 log units) above what was measured; the range from low to high includes it.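

In this assay, 3-methylbut-2-en-1-yl in place of hydrogen on the oxygen on the aromatic ring gives an at least 1.0-fold lower number from compound 2 to compound 3 (0.03 log units; that floor lies within the scatter). Among these compounds, compound 3, at 92000 nM, carries the first value that is a number and not a limit, so this oxygen gives a point from which later changes can be sized. The change itself cannot be called an improvement, as the floor of the step lies within the scatter and the other two compounds remain at a limit of the assay: the limit of > 100000 nM in this assay, at which 2 of the 3 values shown sit.

From the compounds shown here alone, the real size of this step remains open. Also open, going by these compounds, is whether a longer chain, an amine or a carboxylic acid on this oxygen would give a value clearly away from that limit.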